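Swapping (aminocarbamoyl)methoxy for 2-carboxyethyl on a Shared Core

The compounds below may be only part of what the source reports. "The series", "measured", "known", "first", "only" and "open" are said of these compounds alone.

Compound 1 `NNC(=O)COc1ccncc1-c1ccc2ccccc2c1` gives 19% in an assay on a protein complex for inhibition of CDK8/Cyclin C (Homo sapiens), with a stated time of 1 h, tested at 10 uM; a lower number here means less inhibition, a higher number more inhibition at the concentration tested (going by the name of the read-out). Among the three compounds measured, compound 1 stands lowest. Compound 2 `CCOC(=O)/C=C/c1ccncc1-c1ccc2[nH]ccc2c1` gives 100% in this assay, and compound 3 `CC(C)[C@@H](NC(=O)/C=C/c1ccncc1-c1ccc2ccccc2c1)C(=O)O` gives 77%; both lie beyond the scatter above compound 1. Compound 4 `O=C(O)CCc1ccncc1-c1ccc2ccccc2c1` has not yet been measured. It differs from compound 1 in one place: 2-carboxyethyl in place of (aminocarbamoyl)methoxy on an aromatic carbon. For the measured compounds named here, no step between measured compounds shares this change, so the direction can only be judged from the values themselves. Going by the values given here, compound 3, the one measured compound carrying a carboxylic acid, gives 77%, well above compound 1. An upward step of modest size is therefore expected, a number 21 percentage points higher from compound 1 to compound 4 (beyond the scatter). Compound 4 is estimated at 40%, with a range from 15% to 70%.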

Compound 4, a percentage reported as inhibition, at one concentration (the size of the read-out at that concentration, not a potency): 101%
Compound 4: middle estimate off by 61 percentage points, on the low side, outside the stated range (above it).
By their numbers in this assay, from the lowest: compound 1; then compound 3; then compounds 2 and 4 (each within the scatter of the next).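

For the compounds shown here, this is the first change confined to one place: on the aromatic carbon opposite the ring nitrogen, 2-carboxyethyl in place of (aminocarbamoyl)methoxy moves this assay by a number 82 percentage points higher from compound 1 to compound 4 (beyond the scatter). The group at this position can therefore decide, on its own, between weak and strong inhibition on the shared core. No measurement shown accounts for the size of this step. Still open, as far as these compounds go, is whether the carboxylic acid or the chain without its ether oxygen carries the step. From the compounds shown here alone, what a methyl ester or a longer chain would give at this position also remains unknown.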